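A few compounds are considered here, and "the series" means these few. Any claim that something is new, unique, unknown or untested is made for them only; others in the source may bear on it.

Measured compounds:
compound 1 `O=C1C=COC(/C=C/c2ccccc2)C1`: 105 uM
compound 2 `O=C1C=COC(/C=C/c2ccc(C(F)(F)F)cc2)C1`: 51.6 uM
compound 3 `O=C1C=CCC(/C=C/c2ccccc2)N1`: 967 uM

All three were run in a functional assay on NCI/ADR cells (Homo sapiens) for inhibition, read by sulforhodamine B assay, with a stated time of 48 h; on this read-out higher numbers stand for weaker inhibition of growth and lower numbers for stronger inhibition of growth. Compound 1 and compound 2 share one core; the change between them is trifluoromethyl in place of hydrogen on an aromatic carbon and gives a 2.0-fold lower number from compound 1 to compound 2 (0.31 log units; beyond the scatter). Compound 3 carries a different core; the difference between the two cores is not broken down here. Within this set compound 3 stands highest, and its gap to compound 1 and to compound 2 is beyond the scatter.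

Compound 4 `O=C1C=CCC(/C=C/c2ccccc2C(F)(F)F)N1` is not yet measured. It differs from compound 3 by trifluoromethyl in place of hydrogen on an aromatic carbon. This is the same kind of change as that from compound 1 to compound 2, but the surroundings differ: in compound 2 the trifluoromethyl sits para to a group of 9 heavy atoms, in compound 4 it sits ortho to a group of 9 heavy atoms. Within the data shown here, only one earlier instance exists, on the other core, so the expectation is loose. The step from compound 3 to compound 4 is expected to be about a 1.8-fold lower number from compound 3 to compound 4 (0.25 log units; within the scatter), resting on the modest step seen from compound 1 to compound 2. Compound 4 is therefore estimated at 550 uM, with a range from 250 uM to 1200 uM.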

Compound 4, concentration for growth inhibition (reported as GI): 40.6 uM
Estimate against measurement, compound 4: 14-fold (1.13 log units) above; measured number below the stated range.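

In this assay trifluoromethyl in place of hydrogen lowers the number on both cores, but the size of the step does not carry from one core to the other: the same change on two cores in this assay, a 2.0-fold lower number (0.31 log units; beyond the scatter) from compound 1 to compound 2 and a 24-fold lower number (1.38 log units; beyond the scatter) from compound 3 to compound 4, 12-fold (1.07 log units) apart, beyond the scatter of two such steps On the core of compound 3 the step is large, a 24-fold lower number from compound 3 to compound 4 (1.38 log units; beyond the scatter), so the modest step on the core of compound 1 gives no usable guide to its size there. The two steps differ in place as well as in core, since in compound 4 the trifluoromethyl sits ortho to a group of 9 heavy atoms and in compound 2 it sits elsewhere on the ring, so the gap cannot be assigned to the core alone, and one pair per core sets no rule for the series.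

Open, on these data alone, is which of the two differences sets the size of the step, a question that matching placements of the trifluoromethyl on both cores would settle. Also open, as far as these compounds go, is whether a chlorine, a methoxy or a nitrile at the same place would follow the trifluoromethyl on either core.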